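The source may hold more compounds than are shown below. What is called first, only, known or untested is meant among the compounds shown, and "the series" means these compounds.

In a functional assay on P388 cells (Mus musculus) for inhibition (on this read-out lower numbers stand for stronger inhibition and higher numbers for weaker inhibition), compound 1 `CC(=O)Oc1ccc(/C=C/c2ccc3ccccc3c2)cc1` gives > 5000 nM, which is a limit of the assay and not a number. Going by these compounds, compound 3 `FC(F)(F)Oc1ccc(/C=C/c2ccc3ccccc3c2)cc1` gives > 5000 nM, which is also only a limit, so its true standing is unknown. Among the measured compounds shown here, compound 2 `COc1cccc(/C=C\c2ccc3ccccc3c2)c1` is the only one with a measured number, at 1920 nM.

Compound 4 `CN(C)c1ccc(/C=C/c2ccc3ccccc3c2)cc1` carries dimethylamino in place of trifluoromethoxy on an aromatic carbon, para to a large group: dimethylamino in place of trifluoromethoxy on an aromatic carbon.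

For the measured compounds named here, the only measured single change is a step that the two limits leave unreadable from compound 1 to compound 3, and it offers no size to carry over. Both of its ends sit at the limit of > 5000 nM in this assay, at which 2 of the 3 values shown sit. The expectation therefore stays near the limit, and a further limit is quite possible. Going by the values given here, compound 2 at 1920 nM is the only reading of a real number. The expected change, weak and without firm direction, is an at least 1.2-fold lower number from compound 3 to compound 4 (0.09 log units; that floor lies within the scatter). The estimate for compound 4 is 4000 nM, with an expected range from 1200 nM to 10000 nM.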

Compound 4, half-maximal inhibitory concentration: 3660 nM
Beside the measured number, compound 4's estimate is 1.1-fold (0.04 log units) above it, and the stated range covers the measured number.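

In this assay compound 4 gives 3660 nM, which makes dimethylamino the first group shown on an aromatic carbon, para to a large group, to return a real number rather than a limit. Placing dimethylamino there gives an at least 1.3-fold lower number from compound 3 to compound 4 (0.13 log units; that floor lies within the scatter) and an at least 1.3-fold lower number from compound 1 to compound 4 (0.13 log units; that floor lies within the scatter), and since both floors lie within the scatter, neither step yet proves a real gain in inhibition. The true size of both steps stays unknown because compound 1 and compound 3 each sit at a limit of the assay and not at a number: the limit of > 5000 nM in this assay, at which 2 of the 4 values shown sit.

Going by these compounds, what a primary amine, a hydroxyl or a carboxylic acid would give at this same place stays open, as does the effect of longer chains on the nitrogen of dimethylamino. Compound 2 differs from compound 4 in more than one place, so how its methoxy group compares with dimethylamino also remains unresolved.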